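A few compounds are considered here, and "the series" means these few. Any claim that something is new, unique, unknown or untested is made for them only; others in the source may bear on it.

Compound 3, `Cc1oc(C(=O)O)cc1COc1ccc(-c2ccccc2)cc1`, was tested in an assay on cells for displacement of a labelled ligand from prostaglandin E2 receptor EP4 subtype (Homo sapiens), read by scintillation counting (a higher number here means a weaker inhibitor, a lower number a stronger inhibitor), where compound 3 gives 420 nM. Compound 2, `O=C(O)c1cc(COc2ccc(-c3ccccc3)cc2)co1`, gives 2000 nM in this assay. Compound 1, `Cc1oc(C(=O)O)cc1COc1ccc(-c2ccncc2)cc1`, returns only a limit of this assay, > 10000 nM, not a number; this is the limit of > 10000 nM in this assay, at which 1 of the 3 values shown sits. Of the two plain numbers, compound 3 holds the lower one. Two measured steps lead to compound 3: an at least 23-fold lower number from compound 1 to compound 3 (1.37 log units; beyond the scatter), and a 4.8-fold lower number from compound 2 to compound 3 (0.68 log units; beyond the scatter).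

Compound 4, `CC(=O)c1ccc(-c2ccc(OCc3cc(C(=O)O)oc3C)cc2)cc1`, differs from compound 3 in a single place: acetyl in place of hydrogen on an aromatic carbon. For the measured compounds named here, no measured step attaches a group at this place on the six-membered aromatic ring of carbon only, so neither step speaks to it directly; the step from compound 1 to compound 3 only shows that exchanging that ring moves the number greatly. With no closer guide, a change roughly within the scatter is expected, a 1.1-fold lower number from compound 3 to compound 4 (0.02 log units; within the scatter), and compound 4 is estimated at 400 nM, likely between 90 nM and 1800 nM.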

Compound 4, inhibition constant: 150 nM
For compound 4 the middle estimate is 2.7-fold (0.43 log units) above the measured one; low and high end bracket the measured number.
By their numbers in this assay, from the lowest: compound 4; then compound 3; then compound 2. At a limit, above all of these: compound 1.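

For the compounds shown here, until now, the only change to this six-membered aromatic ring of carbon only was the exchange of the whole ring; here the ring stays and a group is added to it, para to a large group. In this assay, acetyl in place of hydrogen gives a 2.8-fold lower number from compound 3 to compound 4 (0.45 log units; beyond the scatter), so this place accepts a group of 3 heavy atoms, and the number falls rather than rises. Nothing in the available evidence bears on why this group lowers the number.

A single group at a single place cannot show whether acetyl itself matters or whether other groups there, such as a nitrile, an amine or a carboxylic acid, would do the same. Going by these compounds, it also remains open whether a longer chain ending in a carbonyl would lower the number further.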